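The compounds below may be only part of what the source reports. "The series", "measured", "known", "first", "only" and "open" are said of these compounds alone.

Series notes. Compound 1 `COc1ccc(Nc2cc(C)oc(=O)c2)cc1` in a functional assay on KB cells (Homo sapiens) for cytotoxicity, read by MTT assay, with a stated time of 72 h (on this read-out higher numbers stand for an effect only at larger amounts of compound and lower numbers for an effect already at smaller amounts), gives > 30 uM, which is a limit of the assay and not a number. On the values shown compound 1 therefore stands at the upper end, as the limit of > 30 uM in this assay, at which 1 of the 2 values shown sits, records. Compound 2 `COc1ccc(Nc2cc(-c3ccc4ccccc4c3)oc(=O)c2)cc1` in this assay gives 0.18 uM. Compound 3 `COc1ccc(Nc2cc(-c3ccco3)oc(=O)c2)cc1` carries furan-2-yl in place of methyl on an aromatic carbon. For the measured compounds named here, no measured step covers this change, so its size is uncertain. For compound 3 the expected step in this assay is an at least 6.0-fold lower number from compound 1 to compound 3 (0.77 log units; beyond the scatter), toward lower concentrations. Compound 3 is estimated at 5 uM, in a range from 1 uM to 30 uM.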

Compound 3, concentration for half-maximal effect: 2.66 uM
For compound 3 the middle estimate is 1.9-fold (0.27 log units) above the measured one; measured number inside the range.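

With furan-2-yl in place of methyl on the aromatic carbon next to the ring oxygen, a single five-membered aromatic ring with 1 hetero atom is enough to bring a measurable effect in this assay, with an at least 11-fold lower number from compound 1 to compound 3 (1.05 log units; beyond the scatter). The size of this step is only a bound, as compound 1 stands at a limit of the assay and not at a number: the limit of > 30 uM in this assay, at which 1 of the 3 values shown sits.

Open, as far as these compounds go, is whether the oxygen of the furan-2-yl ring matters, which thiophen-2-yl or phenyl at this carbon would test. Also open, from the compounds shown here alone, is how an aminomethyl group there would read.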